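A few compounds are considered here, and "the series" means these few. Any claim that something is new, unique, unknown or untested is made for them only; others in the source may bear on it.

In a physicochemical assay for solubility, read by HPLC, at pH 7.4 (on this read-out higher numbers stand for higher solubility and lower numbers for lower solubility), compound 1 `Cc1[nH]c2ccccc2c(=O)c1Cc1ccccc1` gives 10000 nM. Compound 2 `C=C(CCCCCCC)c1c(C)[nH]c2ccccc2c1=O` reads < 2000 nM, which is a limit of the assay and not a number. Compound 3 `COc1cccc2c(=O)c(Cc3ccccc3)c(C)[nH]c12` reads > 20000 nM, and this too is only a limit, so its place on the scale is not fixed by a number. Compound 4 `Cc1[nH]c2c(Cl)cccc2c(=O)c1Cc1ccccc1`, not yet measured, has chloro in place of methoxy on an aromatic carbon, ortho to a fused ring: chloro in place of methoxy on an aromatic carbon. Among the measured compounds shown here, only one measured step bears on this change: an at least 2.0-fold higher number from compound 1 to compound 3 (0.30 log units; that floor lies within the scatter). For the measured compounds named here, it covers methoxy in place of hydrogen, and no measured step covers chloro. With the methoxy gone, the expectation leans on compound 1 at 10000 nM, which also lacks it, and so a modest drop in this assay is expected. The expected step is an at least 2.5-fold lower number from compound 3 to compound 4 (0.39 log units; beyond the scatter). For compound 4 the estimated value is 8000 nM, within an expected range of 3000 nM to 20000 nM.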

Compound 4, solubility: 5000 nM
The estimate for compound 4 lay 1.6-fold (0.20 log units) above the measured number; the measured number falls inside the stated range.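

In this assay, chloro in place of methoxy on this aromatic carbon, ortho to a fused ring, gives an at least 4.0-fold lower number from compound 3 to compound 4 (0.60 log units; beyond the scatter), and this step lies beyond the scatter. Compound 3 stands at a limit of the assay and not at a number: the limit of > 20000 nM in this assay, at which 1 of the 4 values shown sits. Chloro in place of hydrogen at the same place gives a 2.0-fold lower number from compound 1 to compound 4 (0.30 log units; within the scatter), so on these values the two cannot be told apart, while the change from methoxy to chloro can.

The compounds shown leave open how large the step from methoxy truly is, as the limit fixes only its floor. They also leave open how an amine, a carboxylic acid or a longer ether chain on this aromatic carbon would read in this assay.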